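The source may hold more compounds than are shown below. What is called first, only, known or untested is meant among the compounds shown, and "the series" means these compounds.

Compound 1 `O=C(CBr)N1N=C(c2ccc(F)cc2)CC1c1ccccc1O`: 6000 nM
Compound 2 `O=C(CN1CCCCC1)N1N=C(c2ccc(F)cc2)CC1c1ccccc1O`: 8020 nM
Compound 3 `O=C(CN1CCCCC1)N1N=C(c2ccc(Cl)cc2)CC1c1ccccc1O`: 7250 nM

All three were tested in an assay on isolated protein for inhibition of Amine oxidase [flavin-containing] A (Homo sapiens), read by fluorescence, with stated times of 15 min and 20 min; on this read-out higher numbers stand for weaker inhibition and lower numbers for stronger inhibition. Compound 1 gives 6000 nM in this assay, compound 2 gives 8020 nM, and compound 3 gives 7250 nM. Compound 2 sits among the others within the usual scatter: the step of a 1.3-fold higher number from compound 1 to compound 2 (0.13 log units; within the scatter) and the step of a 1.1-fold lower number from compound 2 to compound 3 (0.04 log units; within the scatter) are both too small to tell the compounds apart, so none of the three can be called the stronger or the weaker inhibitor.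

Compound 4 `O=C(Cn1ccnc1)N1N=C(c2ccc(F)cc2)CC1c1ccccc1O` has not yet been measured. It differs from compound 2 in one place: 1H-imidazol-1-yl in place of piperidin-1-yl on a saturated chain carbon bound to a carbonyl carbon. For the measured compounds named here, only one measured step touches this position, the exchange of bromo for piperidin-1-yl, which gave a 1.3-fold higher number from compound 1 to compound 2 (0.13 log units; within the scatter) and stayed within the scatter. The swap of fluoro for chloro on the aromatic carbon, a 1.1-fold lower number from compound 2 to compound 3 (0.04 log units; within the scatter), lies elsewhere and also stayed within the scatter. Nothing in these three compounds shows this position to move the read-out, so compound 4 is expected to give a number close to that of compound 2, with a step of a 1.0-fold lower number from compound 2 to compound 4 (0.00 log units; within the scatter) that is not expected to go beyond the scatter in either direction. The estimate for compound 4 in this assay is 8000 nM, within a range from 4000 nM to 16000 nM.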

Compound 4, half-maximal inhibitory concentration: 26300 nM
For compound 4 the middle estimate is 3.3-fold (0.52 log units) below the measured one; measured number outside the range, above it.
By their numbers in this assay, from the lowest: compounds 1, 3 and 2 (each within the scatter of the next); then compound 4.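

In this assay, the saturated chain carbon bound to a carbonyl carbon turns out to be a place where a change can move the read-out: 1H-imidazol-1-yl in place of piperidin-1-yl gives a 3.3-fold higher number from compound 2 to compound 4 (0.52 log units; beyond the scatter), a modest step, whereas the earlier exchange of bromo for piperidin-1-yl stayed within the scatter. 1H-imidazol-1-yl in place of bromo gives a 4.4-fold higher number from compound 1 to compound 4 (0.64 log units; beyond the scatter), also modest and beyond the scatter, so of the three groups shown at this place, only 1H-imidazol-1-yl stands apart, on the side of weaker inhibition. The change replaces a six-membered non-aromatic ring with 1 hetero atom by a five-membered aromatic ring with 2 hetero atoms, and nothing available here tells which part of that difference accounts for the step.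

Going by these compounds, it remains open whether a morpholin-4-yl group or a 1H-pyrazol-1-yl group at this place would fall with piperidin-1-yl or with 1H-imidazol-1-yl. Also open, on these data alone, is whether chloro in place of fluoro on the aromatic carbon, which stayed within the scatter with piperidin-1-yl on the chain, would do the same with 1H-imidazol-1-yl there.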